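Aryl amide change from compound 2

The source may report more compounds than this note shows. Statements on the series, on what has been measured and on what is new or still open speak of the compounds shown alone.

Measured so far in a functional assay on A549 cells (Homo sapiens) for inhibition, read by CCK-8 assay, with a stated time of 72 h, tested at 1 uM (a lower number here means less inhibition of growth, a higher number more inhibition of growth at the concentration tested), as percent growth inhibition
- compound 1 `CN(C)C(=O)c1cc2cnc(Nc3ccc(NC(=O)C4(C(=O)Nc5ccccc5F)CC4)cc3)nc2n1C1CCCC1` gives 79.1%
- compound 2 `Cc1ccc(NC(=O)C2(C(=O)Nc3ccc(Nc4ncc5cc(C(=O)N(C)C)n(C6CCCC6)c5n4)cc3)CC2)cc1` gives 40.2%

Compound 2 holds the lower of the two numbers and lies beyond the scatter under compound 1. Compound 3 `COc1cccc(NC(=O)C2(C(=O)Nc3ccc(Nc4ncc5cc(C(=O)N(C)C)n(C6CCCC6)c5n4)cc3)CC2)c1` carries 3-methoxyphenyl in place of 4-methylphenyl on an amide-type nitrogen and is otherwise the same. Within the data shown here, the only measured step at this place is a number 38.9 percentage points lower from compound 1 to compound 2 (beyond the scatter) and it shows that a swap on this nitrogen can shift the number widely. Among the measured compounds shown here, no measured compound carries 3-methoxyphenyl, so the direction is weakly supported. A small rise from the low position of compound 2 is expected, possibly within the scatter. The expected step is a number 7.8 percentage points higher from compound 2 to compound 3 (within the scatter) as a rough estimate. For compound 3 the estimated value is 48% with an expected range of 25% to 72% in repeat measurements.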

Compound 3, percent growth inhibition at one concentration: 77.2%
Beside the measured number, compound 3's estimate is 29.2 percentage points below it; the whole stated range lies below it.
By their numbers in this assay, from the lowest: compound 2; then compounds 3 and 1 (each within the scatter of the next).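

The step of a number 37 percentage points higher from compound 2 to compound 3 (beyond the scatter) in this assay shows that the low number of compound 2 does not apply to every replacement of 2-fluorophenyl on this amide-type nitrogen, since another aryl group without fluorine can bring the number back up. With a number 1.9 percentage points lower from compound 1 to compound 3 (within the scatter) as the second new step, 3-methoxyphenyl and 2-fluorophenyl cannot be told apart here, so fluorine is not required for a high number in this small set. Nothing at hand bears on the origin of these steps.

Group and ring position change together across these three compounds, so 4-methoxyphenyl and 3-methylphenyl would be needed to separate the two. Also open, as far as these compounds go, is how this nitrogen tolerates an aryl ring carrying a carboxylic acid or a dimethylamino group, or an alkyl chain in place of the ring.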